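Moving the carboxylic acid and trading methyl for hydroxy

The compounds below may be only part of what the source reports. "The series", "measured", "known", "first", "only" and "open" are said of these compounds alone.

Compound 1 `Cc1c(OCCCCOc2ccc(C(=O)O)c(Cl)c2)ccc(C(=O)CC(C)C)c1C` carries a chain that ends in a 4-carboxy-3-chlorophenyl group. In an assay on HEK293 cells for positive allosteric modulation of metabotropic glutamate receptor 2 (Rattus norvegicus), read by thallium flux, with a stated time of 2.5 min (a lower number here means that less compound is needed, a higher number that more compound is needed for the effect), compound 1 gives > 10000 nM, which is a limit of the assay and not a number (the limit of > 10000 nM in this assay, at which 1 of the 3 values shown sits). Compound 2 `Cc1c(OCCCCOc2ccccc2C(=O)O)ccc(C(=O)CC(C)C)c1C` differs from compound 1 by 2-carboxyphenyl in place of 4-carboxy-3-chlorophenyl on an oxygen on a saturated carbon; in this assay compound 2 gives 976 nM, so there is an at least 10-fold lower number from compound 1 to compound 2 (1.01 log units; beyond the scatter). Compound 3 `Cc1c(OCCCCOc2ccc(C(=O)O)c(Cl)c2)ccc(C(=O)CC(C)C)c1O` differs from compound 1 by hydroxy in place of methyl on an aromatic carbon; in this assay compound 3 gives 151 nM, which is an at least 66-fold lower number from compound 1 to compound 3 (1.82 log units; beyond the scatter). Compound 4 `Cc1c(OCCCCOc2ccccc2C(=O)O)ccc(C(=O)CC(C)C)c1O` has not yet been measured. It differs from compound 3 by 2-carboxyphenyl in place of 4-carboxy-3-chlorophenyl on an oxygen on a saturated carbon, the same change that turned compound 1 into compound 2, now made on the core of compound 3. That earlier step is only a lower bound on the true gain because its starting point is a limit (the limit of > 10000 nM in this assay, at which 1 of the 3 values shown sits). A modest further gain is expected, a 2.5-fold lower number from compound 3 to compound 4 (0.40 log units; beyond the scatter). For compound 4 the estimate in this assay is 60 nM, with a range expected from 15 nM to 300 nM.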

Compound 4, half-maximal effective concentration: 415 nM
Estimate against measurement, compound 4: 6.9-fold (0.84 log units) below; the measured number lies above the stated range.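

On the core of compound 3, the swap to 2-carboxyphenyl gives a 2.7-fold higher number from compound 3 to compound 4 (0.44 log units; beyond the scatter) in this assay, so this change does not carry over from the core of compound 1, where the step ran the other way: the same change on two cores in this assay, an at least 10-fold lower number (1.01 log units; beyond the scatter) from compound 1 to compound 2 and a 2.7-fold higher number (0.44 log units; beyond the scatter) from compound 3 to compound 4, at least 28-fold (1.44 log units) apart, beyond the scatter of two such steps Hydroxy in place of methyl lowers the number on both cores, here with a 2.4-fold lower number from compound 2 to compound 4 (0.37 log units; beyond the scatter), but the size of the step does not carry over either: the same change on two cores in this assay, an at least 66-fold lower number (1.82 log units; beyond the scatter) from compound 1 to compound 3 and a 2.4-fold lower number (0.37 log units; beyond the scatter) from compound 2 to compound 4, at least 28-fold (1.44 log units) apart, beyond the scatter of two such steps Compound 1 stands at a limit and not a number, so both gaps are minimum sizes, and the four compounds show that each change depends on the core it is made on, but not why: the limit of > 10000 nM in this assay, at which 1 of the 4 values shown sits.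

The swap alters two things at once, the place of the carboxylic acid and the chlorine, and the compounds shown do not separate them. Also open, going by these compounds, is whether a 4-carboxyphenyl group without the chlorine, or a tetrazole in place of the carboxylic acid, would behave alike on the two cores.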